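The source may hold more compounds than are shown below. What is called first, only, known or untested is meant among the compounds shown, and "the series" means these compounds.

Compound 1 `CC(C)n1ncc2c(C(=O)Nc3ccccc3)cccc21` is tested in a functional assay on MGC-803 cells (Homo sapiens) for inhibition, read by MTT assay, with a stated time of 72 h (on this read-out higher numbers stand for weaker inhibition and lower numbers for stronger inhibition), where compound 1 gives 38500 nM. Compound 2 `CC(C)n1ncc2c(C(=O)NCc3ccccc3)cccc21` carries a benzyl in place of phenyl on the amide-type nitrogen. In this assay compound 2 reaches only a limit, > 40000 nM. The step of an at least 1.0-fold higher number from compound 1 to compound 2 (0.01 log units; that floor lies within the scatter) thus stays within the scatter. Compound 3 `CC(C)n1ncc2c(C(=O)NCc3cn(-c4ccc([N+](=O)[O-])cc4)nn3)cccc21` carries a larger substituent on that same nitrogen. In this assay compound 3 likewise reaches only a limit, > 40000 nM. Compound 3 therefore stands at the limit of > 40000 nM in this assay, at which 2 of the 3 values shown sit, and not at a number.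

Compound 4 `CCc1ccc(-n2cc(CNC(=O)c3cccc4c3cnn4C(C)C)nn2)cc1` differs from compound 3 by ethyl in place of nitro on an aromatic carbon. No measured step concerns this change; the only step shown, an at least 1.0-fold higher number from compound 1 to compound 2 (0.01 log units; that floor lies within the scatter), touches another part of the molecule and lies within the scatter. With nothing beyond the scatter in hand, no shift beyond the scatter is expected in this assay, and a limit is again the likely outcome. Compound 4 is expected at 40000 nM, between 15000 nM and 100000 nM. The expected step is a number no higher from compound 3 to compound 4 (the limit leaves the size open).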

Compound 4, half-maximal inhibitory concentration: > 40000 nM
Compound 4 gave a limit, no number (the forecaster's own chance of this, stated with the estimate: 60%); the middle value lies on the limit itself.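

Compound 3 and compound 4 both end at a limit and not at a number in this assay, so the step between them cannot be read: the limit of > 40000 nM in this assay, at which 3 of the 4 values shown sit.

On these data alone, whether any other group on that aromatic carbon would give a number and not a limit in this assay stays open.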